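The source may hold more compounds than are shown below. What is called first, only, known or untested is meant among the compounds shown, and "the series" means these compounds.

Compound 1 `CCCCCCCCNc1nc(SCc2ccc(C(F)(F)F)cc2)nc2ccccc12`: in a functional assay on MCF7 cells (Homo sapiens) for cytotoxicity, read by MTT assay, with a stated time of 72 h (a lower number here means a stronger inhibitor, a higher number a weaker inhibitor), compound 1 gives 26100 nM.
Compound 2 `O=[N+]([O-])c1ccc(Nc2nc(SCc3ccc(C(F)(F)F)cc3)nc3ccccc23)cc1`: in this assay compound 2 gives 17900 nM.
Compound 3 `Cc1ccc(Nc2nc(SCc3ccc(C(F)(F)F)cc3)nc3ccccc23)cc1`: in this assay compound 3 is recorded only as > 50000 nM, which is a limit of the assay and not a number.

Compound 3 therefore stands at the weak end of the three measured compounds, its true value unknown beyond that limit (the limit of > 50000 nM in this assay, at which 1 of the 3 values shown sits). The step of an at least 1.9-fold higher number from compound 1 to compound 3 (0.28 log units; that floor lies within the scatter) stays within the scatter, while the step of an at least 2.7-fold higher number from compound 2 to compound 3 (0.44 log units; beyond the scatter) is beyond it. Compound 4 `COc1cc(Nc2nc(SCc3ccc(C(F)(F)F)cc3)nc3ccccc23)cc(OC)c1` is the next compound to be measured; it differs from compound 3 in one place: 3,5-dimethoxyphenyl in place of 4-methylphenyl on a nitrogen on an aromatic ring. For the measured compounds named here, no measured step exchanges one substituted phenyl for another on this nitrogen and ends in a number. Going by the values given here, the only guide is that the nitro-bearing compound 2 sits at 17900 nM in this assay. The methyl-bearing compound 3, for its part, is recorded only as a limit of the assay. Compound 4 is therefore expected to remain weak, with a step of an at least 1.2-fold lower number from compound 3 to compound 4 (0.09 log units; that floor lies within the scatter) that may well not be seen as a number at all. The estimate for compound 4 in this assay is 40000 nM, within 15000 nM to 150000 nM.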

Compound 4, half-maximal inhibitory concentration: 6990 nM
Compound 4: middle estimate off by 5.7-fold (0.76 log units), on the high side, and the stated range ends above it.
By their numbers in this assay, from the lowest: compound 4; then compounds 2 and 1 (each within the scatter of the next). At a limit, above all of these: compound 3.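

For the compounds shown here, on this nitrogen, the 3,5-dimethoxyphenyl group gives the first steps in this assay that end in a number and lie beyond the scatter: a 2.6-fold lower number from compound 2 to compound 4 (0.41 log units; beyond the scatter), and a 3.7-fold lower number from compound 1 to compound 4 (0.57 log units; beyond the scatter). The substituents on the phenyl ring therefore matter here, as compounds 2, 3 and 4 all carry that ring yet do not read alike. Against 4-methylphenyl the change reads as an at least 7.1-fold lower number from compound 3 to compound 4 (0.85 log units; beyond the scatter), which is only a floor, as compound 3 stands at a limit and not at a number: the limit of > 50000 nM in this assay, at which 1 of the 4 values shown sits.

The compounds shown leave open whether both methoxy groups are needed, or whether a single methoxy, a hydroxyl or an amine on the phenyl ring would do as well. They also leave open how a shorter chain such as butyl would compare with octyl on this nitrogen.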